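Amide series: ring-to-chain change at the amino substituent

The compounds below may be only part of what the source reports. "The series", "measured", "known", "first", "only" and "open" are said of these compounds alone.

Compound 3 `CC1CCN(c2ccc3cc(NC(=O)CCc4ccc(C(F)(F)F)cc4)ccc3n2)C1` carries a 3-methylpyrrolidin-1-yl group on the shared core and gives 400 nM in a functional assay on HEK293 cells for activation of melanin-concentrating hormone receptor 1 (Rattus norvegicus), read by inositol phosphate accumulation (a lower number here means that less compound is needed, a higher number that more compound is needed for the effect), the highest of the three numbers measured. Compound 2 `CC1CCCN1c1ccc2cc(NC(=O)CCc3ccc(C(F)(F)F)cc3)ccc2n1` gives 270 nM and compound 1 `CC(C)N(C)c1ccc2cc(NC(=O)CCc3ccc(C(F)(F)F)cc3)ccc2n1` gives 140 nM. The step of a 1.5-fold higher number from compound 2 to compound 3 (0.17 log units; within the scatter) lies within the scatter, the step of a 2.9-fold higher number from compound 1 to compound 3 (0.46 log units; beyond the scatter) is modest but beyond it, and the step of a 1.9-fold higher number from compound 1 to compound 2 (0.29 log units; within the scatter) is within the scatter.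

Compound 4 `CN(C)c1ccc2cc(NC(=O)CCc3ccc(C(F)(F)F)cc3)ccc2n1` is reached by the change (dimethylamino in place of 3-methylpyrrolidin-1-yl on an aromatic carbon). The step that bears on it most directly is a 2.9-fold higher number from compound 1 to compound 3 (0.46 log units; beyond the scatter), which it reverses in kind: a ring leaves, an acyclic amine enters. Going by the values given here, compound 1 with its acyclic amine gives 140 nM, so a return toward that number is expected, though no measured step covers dimethylamino itself. The expected step is a 2.2-fold lower number from compound 3 to compound 4 (0.35 log units; beyond the scatter), towards a lower number. Compound 4 is estimated at 180 nM, with a range from 70 nM to 450 nM.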

Compound 4, half-maximal effective concentration: 110 nM
Compound 4: middle estimate off by 1.6-fold (0.21 log units), on the high side, and the stated range covers the measured number.
By their numbers in this assay, from the lowest: compounds 4, 1, 2 and 3 (each within the scatter of the next, the first and the last beyond it).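

In this assay, dimethylamino separates from both ring amines, with a 3.6-fold lower number from compound 3 to compound 4 (0.56 log units; beyond the scatter) and a 2.5-fold lower number from compound 2 to compound 4 (0.39 log units; beyond the scatter) each lying beyond the scatter, whereas compound 2 could not be separated from compound 1 by a 1.9-fold higher number from compound 1 to compound 2 (0.29 log units; within the scatter) alone. With a 1.3-fold lower number from compound 1 to compound 4 (0.10 log units; within the scatter) inside the scatter, methyl in place of isopropyl on the nitrogen leaves the two acyclic amines indistinguishable at this position next to the ring nitrogen. The ring-to-chain contrast therefore holds for compound 4 against both rings and for compound 1 against compound 3, with the pair of compound 1 and compound 2 going against it.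

On these data alone, whether unsubstituted pyrrolidine, piperidine, morpholine or diethylamino would fall with the acyclic amines or with the methylpyrrolidines remains open. No supporting data on the origin of these steps are available.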